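Swapping the aryl ring on the chalcone carbonyl of compound 2

A few compounds are considered here, and "the series" means these few. Any claim that something is new, unique, unknown or untested is made for them only; others in the source may bear on it.

Measured compounds:
Compound 1 `COc1cc(-c2cc(/C=C/C(=O)c3ccc(N)cc3)[nH]n2)cc(OC)c1OC` gives 1% in a functional assay on IGROV-1 cells (Homo sapiens) for cytotoxicity, read by sulforhodamine B assay, with a stated time of 48 h, tested at 10 uM; on this read-out higher numbers stand for a weaker effect at the one concentration tested and lower numbers for a stronger effect.
Compound 2 `COc1cc(-c2cc(/C=C/C(=O)c3ccc(Cl)c(Cl)c3)[nH]n2)cc(OC)c1OC` gives 75% in this assay.
Compound 3 `COc1ccc(-c2cc(/C=C/C(=O)c3cc(OC)c(OC)c(OC)c3)[nH]n2)cc1OC` gives -7% in this assay.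

Among these three, compound 2 stands highest in this assay, that is, it shows the weakest effect; compound 1 sits a long way lower and compound 3 further still. Compound 4 `COc1ccc(C(=O)/C=C/c2cc(-c3cc(OC)c(OC)c(OC)c3)n[nH]2)cc1` differs from compound 2 in one place: 4-methoxyphenyl in place of 3,4-dichlorophenyl on a carbonyl carbon. Within the data shown here, one measured step bears on this kind of change: a number 74 percentage points higher from compound 1 to compound 2 (beyond the scatter), showing that exchanging the ring on the carbonyl carbon can move the number a great deal. Compound 3, which also carries a methoxy-bearing ring on its carbonyl carbon though with a different core, gives a low number. A fall beyond the scatter is therefore expected, though its full size is uncertain. Compound 4 is estimated at 25%, with a range from -5% to 65%, which would mean an expected step of a number 50 percentage points lower from compound 2 to compound 4 (beyond the scatter).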

Compound 4, a percentage reported as activity, at one concentration (the size of the read-out at that concentration, not a potency): -47%
For compound 4 the middle estimate is 72 percentage points above the measured one; the whole stated range lies above it.
By their numbers in this assay, from the lowest: compound 4; then compounds 3 and 1 (each within the scatter of the next); then compound 2.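

In this assay, the ring on the carbonyl carbon can move the number even further than the earlier step suggested: the change a number 122 percentage points lower from compound 2 to compound 4 (beyond the scatter) is larger than the earlier a number 74 percentage points higher from compound 1 to compound 2 (beyond the scatter) seen at this same place. The new compound also separates two rings that both gave strong effects, with the change a number 48 percentage points lower from compound 1 to compound 4 (beyond the scatter) showing that methoxy and amino are not interchangeable here, and among compound 1, compound 2 and compound 4, which differ only in this ring, compound 4 shows the strongest effect. No measurement at hand explains why these rings differ so much.

Still open, going by these compounds, is how other groups on this ring would read, such as a hydroxyl, a carboxylic acid or a single chlorine. A single chlorine in particular would help separate the loss of the second chlorine from the arrival of the methoxy.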